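The compounds below may be only part of what the source reports. "The series", "measured", "known", "first", "only" and "open" are said of these compounds alone.

In a functional assay on CHO cells for antagonist activity at prostaglandin D2 receptor (Mus musculus), read by cAMP accumulation (on this read-out lower numbers stand for stronger inhibition and higher numbers for weaker inhibition), compound 2 `Cc1ccc(CC(=O)O)cc1NC(=O)c1ccc(OC[C@@H]2CN(C)c3ccccc3O2)cc1Cl` gives 6 nM, the lowest of the two numbers available. Compound 1 `Cc1cc(OC[C@@H]2CN(C)c3ccccc3O2)ccc1C(=O)Nc1cccc(CC(=O)O)c1C` gives 28 nM in this assay, a number that lies beyond the scatter above that of compound 2. Compound 3 `Cc1ccc(NC(=O)c2ccc(OC[C@@H]3CN(C)c4ccccc4O3)cc2Cl)cc1CC(=O)O` has not been measured in this assay. It keeps every atom of compound 2 but joins them differently: 3-(carboxymethyl)-4-methylphenyl in place of 5-(carboxymethyl)-2-methylphenyl on an amide-type nitrogen. Among the compounds with values here, no step between measured compounds isolates this change, so the direction cannot be read from the data; the carboxymethyl and methyl groups simply exchange their arrangement on the phenyl that sits on the amide nitrogen. A modest weakening is expected, of a size a 2.5-fold higher number from compound 2 to compound 3 (0.40 log units; beyond the scatter), which may still fall within the scatter. Compound 3 is therefore estimated at 15 nM in this assay, with a range from 4 nM to 60 nM.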

Compound 3, half-maximal inhibitory concentration: 3.9 nM
For compound 3 the middle estimate is 3.8-fold (0.59 log units) above the measured one, outside the stated range (below it).
By their numbers in this assay, from the lowest: compounds 3 and 2 (each within the scatter of the next); then compound 1.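

In this assay, 3-(carboxymethyl)-4-methylphenyl in place of 5-(carboxymethyl)-2-methylphenyl on an amide-type nitrogen gives a 1.5-fold lower number from compound 2 to compound 3 (0.19 log units; within the scatter). Within the data shown here, this is the first step that isolates a change on this phenyl, and it shows that the two arrangements of the carboxymethyl and methyl groups cannot be told apart on this read-out, with both compounds giving single-digit numbers. Nothing available explains this result.

On these data alone, whether this tolerance extends to other groups stays open: an ethyl group in place of the methyl, or a longer carboxyethyl chain in place of the carboxymethyl, could behave differently on this phenyl. Compound 1 differs from compound 2 and compound 3 in more than one place, so what its separate changes contribute also remains unresolved.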